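From 4-(trifluoromethyl)phenyl to furan-2-yl on a shared core

The source may report more compounds than this note shows. Statements on the series, on what has been measured and on what is new or still open speak of the compounds shown alone.

In an ADME assay on Vero cells (Chlorocebus sabaeus) for cytotoxicity, read by MTT assay (a higher number here means a weaker inhibitor, a lower number a stronger inhibitor), compound 1 `C=CCOc1cc(OC)c(C(=O)/C=C/c2ccccc2)c(OCC=C)c1` gives 17100 nM and compound 2 `C=CCOc1cc(OC)c(C(=O)/C=C/c2ccc(C(F)(F)F)cc2)c(OCC=C)c1` gives 7200 nM, the lower of the two numbers. For the measured compounds named here, the one measured step, a 2.4-fold lower number from compound 1 to compound 2 (0.38 log units; beyond the scatter), is modest and comes from trifluoromethyl in place of hydrogen on an aromatic carbon. Compound 3 `C=CCOc1cc(OC)c(C(=O)/C=C/c2ccco2)c(OCC=C)c1` changes this same part of the molecule: furan-2-yl in place of 4-(trifluoromethyl)phenyl on a double-bonded chain carbon bound to a double-bonded chain carbon. Going by the values given here, the trifluoromethyl is gone, and no furan has been measured, so that single step is the only guide. A modest move back toward higher numbers is expected, a 2.1-fold higher number from compound 2 to compound 3 (0.32 log units; beyond the scatter). For compound 3 the estimated value is 15000 nM, within a range of 6000 nM to 35000 nM.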

Compound 3, half-maximal inhibitory concentration: 191000 nM
For compound 3 the middle estimate is 13-fold (1.10 log units) below the measured one, outside the stated range (above it).
By their numbers in this assay, from the lowest: compound 2; then compound 1; then compound 3.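

In this assay furan-2-yl gives a 27-fold higher number from compound 2 to compound 3 (1.42 log units; beyond the scatter) and also an 11-fold higher number from compound 1 to compound 3 (1.05 log units; beyond the scatter) on this double-bonded chain carbon. Exchanging the whole ring therefore moves the number much further here than adding trifluoromethyl to phenyl did, so this position is not limited to modest shifts. Nothing available explains why the number rises so sharply. Still open, from the compounds shown here alone, is whether the jump follows the ring oxygen or the five-membered ring, which thiophene, with sulfur in place of oxygen, could separate. Going by these compounds, a pyridine ring or an amine on the phenyl ring also remains unknown here.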